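A Chloro Swap on the Aryl Ether of Compound 3

The compounds below may be only part of what the source reports. "The series", "measured", "known", "first", "only" and "open" are said of these compounds alone.

In an ADME assay on PBMC cells (Homo sapiens) for cytotoxicity (on this read-out higher numbers stand for lower toxicity in this test and lower numbers for higher toxicity in this test), compound 3 (`CC(CCNC(=O)c1c(Cl)cncc1Cl)N1CCC(C(Oc2cc(Cl)ccn2)c2ccc(C(F)(F)F)cc2)CC1`) gives 4260 nM, within the scatter of compound 1 (`CC(CCNC(=O)c1c(Cl)cncc1Cl)N1CCC(C(Oc2cccc(F)c2)c2ccc(C(F)(F)F)cc2)CC1`) at 5400 nM. Both lie well under compound 2 (`CC(CCNC(=O)c1c(Cl)cncc1Cl)N1CCC(C(Oc2ccccn2)c2ccc(C(F)(F)F)cc2)CC1`) at 34100 nM. Compound 4 (`CC(CCNC(=O)c1c(Cl)cncc1Cl)N1CCC(C(Oc2ccccc2Cl)c2ccc(C(F)(F)F)cc2)CC1`) differs from compound 3 by one exchange, (2-chlorophenyl in place of 4-chloropyridin-2-yl on an oxygen on a saturated carbon), with 2-chlorophenyl in place of 4-chloropyridin-2-yl. Among the compounds with values here, three measured steps bear on it. Chloro in place of hydrogen on an aromatic carbon gave an 8.0-fold lower number from compound 2 to compound 3 (0.90 log units; beyond the scatter). Replacing 3-fluorophenyl gave a 1.3-fold lower number from compound 1 to compound 3 (0.10 log units; within the scatter) with 4-chloropyridin-2-yl, but a 6.3-fold higher number from compound 1 to compound 2 (0.80 log units; beyond the scatter) with pyridin-2-yl. Compound 4 retains a chloro group, so no step beyond the scatter is expected, and the expected result is a 1.1-fold higher number from compound 3 to compound 4 (0.02 log units; within the scatter). For compound 4 the estimated value is 4500 nM, with an expected range from 1800 nM to 11000 nM.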

Compound 4, half-maximal cytotoxic concentration: 4400 nM
The estimate for compound 4 lay 1.0-fold (0.01 log units) above the measured number, within the range that was stated.
By their numbers in this assay, from the lowest: compounds 3, 4 and 1 (each within the scatter of the next); then compound 2.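

In this assay, the exchange of 4-chloropyridin-2-yl for 2-chlorophenyl on the oxygen leaves the number in place (a 1.0-fold higher number from compound 3 to compound 4 (0.01 log units; within the scatter)), so a ring of carbon only serves here as well as the chlorinated pyridine. The exchange of 3-fluorophenyl for 2-chlorophenyl is also small (a 1.2-fold lower number from compound 1 to compound 4 (0.09 log units; within the scatter)), while the exchange of pyridin-2-yl for 2-chlorophenyl is not (a 7.8-fold lower number from compound 2 to compound 4 (0.89 log units; beyond the scatter)), which leaves compound 2 alone among the four. No measurement at hand explains this. On these data alone, whether an unsubstituted phenyl, or a ring bearing a methoxy group or an amine, would fall with compound 2 or with the other three stays open.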